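Series notes: piperidine ether variation at the saturated-carbon oxygen

This account rests on a few compounds, and the source may have more. Where it says the series, first, only, none or still open, it means among the compounds named here.

Measured so far:
compound 1 `Cc1cc(C(=O)O)ccc1CN1CCC[C@H](O[C@H](CO)c2ccccc2)[C@@H]1c1ccccc1`: 25000 nM
compound 2 `Cc1cc(C(=O)O)ccc1CN1CCC[C@H](OC(c2cc(Cl)cc(Cl)c2)C(C)O)[C@@H]1c1ccccc1`: 5300 nM

Within the data shown here, in an assay on isolated protein for activation of cGMP-dependent protein kinase 1 (Homo sapiens), read by ADP-Glo, with stated times of 30 min and 2 h, in the presence of a further agent that is not named here (on this read-out higher numbers stand for an effect only at larger amounts of compound and lower numbers for an effect already at smaller amounts), compound 1 gives 25000 nM and compound 2 gives 5300 nM, the lower of the two numbers; the only measured step is a 4.7-fold lower number from compound 1 to compound 2 (0.67 log units; beyond the scatter). Compound 3 `Cc1cc(C(=O)O)ccc1CN1CCC[C@H](O[C@H](CO)c2cccc(Cl)c2)[C@@H]1c1ccccc1` is not yet measured. It differs from compound 2 as follows: a group of 10 heavy atoms (8 carbon, 1 oxygen, 1 chlorine; one six-membered aromatic ring of carbon only) in place of a group of 12 heavy atoms (9 carbon, 1 oxygen, 2 chlorine; one six-membered aromatic ring of carbon only), on an oxygen on a saturated carbon. The entering group resembles that of compound 1, with one chlorine added to its ring, so compound 3 sits structurally between compound 1 and compound 2. Among the measured compounds shown here, the one measured step, a 4.7-fold lower number from compound 1 to compound 2 (0.67 log units; beyond the scatter), changed both the chlorines and the side chain at once, so its size cannot be split between the two parts. Compound 3 is therefore expected to fall between the two measured values, with a step of a 2.1-fold higher number from compound 2 to compound 3 (0.32 log units; beyond the scatter) in this assay, upward. The estimate for compound 3 in this assay is 11000 nM, within 4000 nM to 30000 nM.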

Compound 3, half-maximal effective concentration: 1300 nM
Compound 3: middle estimate off by 8.5-fold (0.93 log units), on the high side, and the stated range ends above it.
By their numbers in this assay, from the lowest: compound 3; then compound 2; then compound 1.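

In this assay, among these compounds, chloro in place of hydrogen on an aromatic carbon gives a 19-fold lower number from compound 1 to compound 3 (1.28 log units; beyond the scatter), the first change made at this one place alone, and so the first to show what the ring substitution does with the chain held constant. Replacing the group of compound 2 with 1-(3-chlorophenyl)-2-hydroxyethyl gives a 4.1-fold lower number from compound 2 to compound 3 (0.61 log units; beyond the scatter), so the group with more chlorine does not carry the lower number here, although that step also alters the chain. No data are available on why either step has this size.

The part played by the second chlorine cannot be separated from that of the extra carbon on the chain. On these data alone, whether fluoro or methoxy could replace the chloro, or an amine the hydroxyl, remains open.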